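Replacing a dimethylcarbamoyl with a methoxycarbonyl-pyridyl ring

The source may report more compounds than this note shows. Statements on the series, on what has been measured and on what is new or still open speak of the compounds shown alone.

Measured compounds:
compound 1, `N#Cc1cccc(-c2cnc(C(=O)CCc3ccc(-c4ccccc4)cc3)o2)n1`, 2.9 nM
compound 2, `CN(C)C(=O)c1cnc(C(=O)CCc2ccc(-c3ccccc3)cc2)o1`, 3 nM

For the measured compounds named here, only two compounds have been measured in an assay for inhibition of Fatty-acid amide hydrolase 1 (Rattus norvegicus); on this read-out lower numbers stand for stronger inhibition and higher numbers for weaker inhibition. Compound 1 gives 2.9 nM and compound 2 gives 3 nM; these two numbers lie within the scatter of each other, so compound 2 cannot be set apart from compound 1 on this read-out. Going by the values given here, the one measured step, a 1.0-fold higher number from compound 1 to compound 2 (0.01 log units; within the scatter), exchanged one group on the shared core for another without moving the number beyond the scatter.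

Compound 3, `COC(=O)c1ccc(-c2cnc(C(=O)CCc3ccc(-c4ccccc4)cc3)o2)cn1`, carries the change (6-(methoxycarbonyl)pyridin-3-yl in place of dimethylcarbamoyl on an aromatic carbon). The step from compound 1 to compound 2 bears on it, since it concerns the same place on the core and the same kind of exchange, between an aromatic ring and the dimethylcarbamoyl, and it was a 1.0-fold higher number from compound 1 to compound 2 (0.01 log units; within the scatter). On that basis no step beyond the scatter is expected in this assay for the reverse direction either. The estimate for compound 3 is therefore 3 nM, between 1 nM and 10 nM, which means an expected step of no change at the digits printed from compound 2 to compound 3 (within the scatter).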

Compound 3, inhibition constant: 0.6 nM
For compound 3 the middle estimate is 5.0-fold (0.70 log units) above the measured one; the whole stated range lies above it.
By their numbers in this assay, from the lowest: compound 3; then compounds 1 and 2 (each within the scatter of the next).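

In this assay this place on the shared core, on an aromatic carbon next to the ring oxygen, proved able to move the number: the earlier pair had shown no step beyond the scatter, whereas the exchange of dimethylcarbamoyl for 6-(methoxycarbonyl)pyridin-3-yl gave a 5.0-fold lower number from compound 2 to compound 3 (0.70 log units; beyond the scatter) and so set compound 3 apart. An aromatic ring at this place does not by itself account for that gain, since exchanging 6-cyanopyridin-2-yl for 6-(methoxycarbonyl)pyridin-3-yl gave a 4.8-fold lower number from compound 1 to compound 3 (0.68 log units; beyond the scatter) even though both groups carry a six-membered aromatic ring with one hetero atom. No measurement at hand explains why these groups differ in this way.

Compound 1 and compound 3 differ both in the substituent on the ring, nitrile against methoxycarbonyl, and in how the ring is named and attached, so the compounds shown do not tell which of these features carries the step. Also open, as far as these compounds go, is what a carboxylic acid in place of the methyl ester, or an unsubstituted pyridin-3-yl group, would give at this place.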